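From chloro to trifluoromethyl in the amide series

The source may hold more compounds than are shown below. What is called first, only, known or untested is meant among the compounds shown, and "the series" means these compounds.

Among the compounds with values here, in a functional assay on HepG2 cells (Homo sapiens) for antiproliferative activity, read by sulforhodamine B assay, with a stated time of 72 h (a lower number here means a stronger inhibitor, a higher number a weaker inhibitor), compound 1 (`O=C(Cn1nc(Cc2ccccc2)c2ccccc2c1=O)Nc1ccc(F)cc1`) gives 27000 nM and compound 2 (`O=C(Cn1nc(Cc2ccccc2)c2ccccc2c1=O)Nc1cccc(Cl)c1`) gives 14300 nM so compound 2 stands within the scatter of the only other measured value. Compound 3 (`O=C(Cn1nc(Cc2ccccc2)c2ccccc2c1=O)Nc1cccc(C(F)(F)F)c1`) carries trifluoromethyl in place of chloro on an aromatic carbon with the rest of the structure unchanged. Within the data shown here, the single measured step (a 1.9-fold lower number from compound 1 to compound 2 (0.28 log units; within the scatter)) lies within the scatter and involves a different exchange of groups on the same amide-type nitrogen, so no step beyond the scatter is expected in this assay for this change. The expected value for compound 3 is 14000 nM (estimated range 6000 nM to 32000 nM).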

Compound 3, half-maximal inhibitory concentration: 3520 nM
Compound 3: middle estimate off by 4.0-fold (0.60 log units), on the high side, and the stated range ends above it.
By their numbers in this assay, from the lowest: compound 3; then compounds 2 and 1 (each within the scatter of the next).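

At this aromatic carbon in this assay, trifluoromethyl in place of chloro gives a 4.1-fold lower number from compound 2 to compound 3 (0.61 log units; beyond the scatter), a modest change but one beyond the scatter, which the earlier pair did not reach. The 3-(trifluoromethyl)phenyl amide also separates from the 4-fluorophenyl amide, with a 7.7-fold lower number from compound 1 to compound 3 (0.88 log units; beyond the scatter), so compound 3 is the strongest of the three. Nothing available accounts for this difference. Open, from the compounds shown here alone, is whether the effect belongs to trifluoromethyl specifically or would also appear with a nitrile or a methoxy group on the same carbon. Also open, going by these compounds, is how trifluoromethyl would read at another ring position.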